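The source may report more compounds than this note shows. Statements on the series, on what has been measured and on what is new or still open speak of the compounds shown alone.

In a physicochemical assay for lipophilicity, read by HPLC, at pH 7.5 (on this read-out lower numbers stand for lower lipophilicity and higher numbers for higher lipophilicity), compound 3 `CCOc1ccccc1-c1ccc(-c2nc3cnccc3c(N[C@H](CC)C(N)=O)c2C#N)cc1` gives 3. Compound 1 `CC[C@@H](Nc1c(C#N)c(-c2ccc(-c3cccc(C)c3)cc2)nc2cnccc12)C(N)=O` gives 3, level with it at the top of the three numbers, while compound 2 `CC[C@@H](Nc1c(C#N)c(-c2ccc(-c3ccncc3C)cc2)nc2cnccc12)C(N)=O` gives 2.

The next compound to consider is compound 4 `CC[C@@H](Nc1c(C#N)c(-c2ccc(-c3ccccc3CO)cc2)nc2cnccc12)C(N)=O`, which has one change from compound 3: hydroxymethyl in place of ethoxy on an aromatic carbon. Seen one bond further out, this is 2-ethoxyphenyl to 2-(hydroxymethyl)phenyl.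

For the measured compounds named here, no measured step makes this exact swap, so the evidence is indirect. Three measured steps do exchange the aromatic group at this part of the molecule. Placing 2-ethoxyphenyl where 3-methylphenyl stood gave no change at the digits printed from compound 1 to compound 3 (within the scatter). Placing 3-methylpyridin-4-yl where 3-methylphenyl stood gave a number 1.00 log units lower from compound 1 to compound 2 (beyond the scatter), and placing 2-ethoxyphenyl where 3-methylpyridin-4-yl stood gave a number 1.00 log units higher from compound 2 to compound 3 (beyond the scatter). Changes here have therefore ranged from nothing visible to modest.

Ethoxy and hydroxymethyl differ in their heavy atoms and hydrogen-bond donors, and a fall is expected from compound 3 at 3, though no measured step tests this directly. The expected step, smaller than the largest seen so far, is a number 0.60 log units lower from compound 3 to compound 4 (beyond the scatter). For compound 4 the estimated value is 2.4, with an expected range from 1.8 to 3.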

Compound 4, distribution coefficient: 2.1
Compound 4: middle estimate off by 0.30 log units, on the high side; measured number inside the range.
By their numbers in this assay, from the lowest: compounds 2 and 4 (each within the scatter of the next); then compounds 1 and 3 (each within the scatter of the next).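

In this assay, for the compounds shown here, the number had so far shifted only when 3-methylpyridin-4-yl stood in place of a carbon-only ring, but a number 0.90 log units lower from compound 3 to compound 4 (beyond the scatter) shows that changing just the side group on such a ring, here ethoxy to hydroxymethyl, can also produce a modest step. The same hydroxymethyl-bearing ring gives a number 0.90 log units lower from compound 1 to compound 4 (beyond the scatter) when set against 3-methylphenyl, yet a number 0.10 log units higher from compound 2 to compound 4 (within the scatter) leaves it level with the 3-methylpyridin-4-yl group, so two quite different groups at this position read alike in this assay and a carbon-only ring does not by itself keep the number at the top of the series. Nothing measured here explains the size of these steps.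

The swap from ethoxy to hydroxymethyl alters the heavy atoms and the hydrogen-bond donors together, so the compounds shown cannot separate the contribution of each. On these data alone, how a methoxymethyl group, a longer 2-hydroxyethyl chain, an aminomethyl group or a carboxylic acid would read at this same place remains open.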